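Thiourea aryl swap: dimethylphenyl to fluorophenyl

The source may hold more compounds than are shown below. What is called first, only, known or untested is meant among the compounds shown, and "the series" means these compounds.

Compound 1 `CNC(=O)c1ccc(Oc2cccc(NC(=S)Nc3ccc(C)cc3)c2)nc1`: in a functional assay on PC-3 cells (Homo sapiens) for antiproliferative activity, read by MTT assay (a higher number here means a weaker inhibitor, a lower number a stronger inhibitor), compound 1 gives > 100000 nM, which is a limit of the assay rather than a number.
Compound 2 `CNC(=O)c1ccc(Oc2cccc(NC(=S)Nc3ccc(C)c(C)c3)c2)nc1`: compound 2 gives 67400 nM.
Compound 3 `CNC(=O)c1ccc(Oc2cccc(NC(=S)Nc3ccc(Br)c(C(F)(F)F)c3)c2)nc1`: compound 3 gives 2670 nM.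

Compound 2 holds the highest of the two numbers; the nearest, compound 3, sits a long way lower. Compound 4 `CNC(=O)c1ccc(Oc2cccc(NC(=S)Nc3ccc(F)cc3)c2)nc1` differs from compound 2 by 4-fluorophenyl in place of 3,4-dimethylphenyl on an amide-type nitrogen. Within the data shown here, the only measured step touching this ring, an at least 1.4-fold lower number from compound 1 to compound 2 (0.17 log units; that floor lies within the scatter), runs downward when a methyl is added; compound 4 removes the methyls and brings in fluorine, on which nothing has been measured. The step is therefore expected to run upward, a 1.5-fold higher number from compound 2 to compound 4 (0.17 log units; within the scatter), toward the limit seen for compound 1 (the limit of > 100000 nM in this assay, at which 1 of the 3 values shown sits). Compound 4 is expected to give 100000 nM, within 40000 nM to 250000 nM.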

Compound 4, half-maximal inhibitory concentration: 32700 nM
For compound 4 the middle estimate is 3.1-fold (0.49 log units) above the measured one, outside the stated range (below it).
By their numbers in this assay, from the lowest: compound 3; then compound 4; then compound 2. At a limit, above all of these: compound 1.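

In this assay, changing the aryl group on this amide-type nitrogen gives a step that can be read, with 4-fluorophenyl in place of 3,4-dimethylphenyl giving a 2.1-fold lower number from compound 2 to compound 4 (0.31 log units; beyond the scatter). Fluoro in place of methyl gives an at least 3.0-fold lower number from compound 1 to compound 4 (0.48 log units; beyond the scatter), so both steps lie beyond the scatter, whereas the floor of the earlier methyl step did not. Compound 1 still stands at a limit: the limit of > 100000 nM in this assay, at which 1 of the 4 values shown sits.

The compounds shown leave open how a methoxy group, an amino group or a carboxylic acid in place of the fluoro would read.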